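Aryl ether change at the low end of the series

The compounds below may be only part of what the source reports. "The series", "measured", "known", "first", "only" and "open" are said of these compounds alone.

For the measured compounds named here, in a functional assay (aorta) with Oryctolagus cuniculus as the target (on this read-out higher numbers stand for weaker binding and lower numbers for tighter binding), compound 2 `CC(C)(C)c1ccc(OCCCN2CCC(C(c3ccc(F)cc3)c3ccc(F)cc3)CC2)cc1` gives 1 nM, the lowest of the two numbers so far, while compound 1 `CC(=O)c1ccc(OCCCN2CCC(C(c3ccc(F)cc3)c3ccc(F)cc3)CC2)cc1` gives 2.51 nM. Compound 3 `Fc1ccc(C(c2ccc(F)cc2)C2CCN(CCCOc3ccc4ccccc4c3)CC2)cc1` has naphthalen-2-yl in place of 4-(tert-butyl)phenyl on an oxygen on a saturated carbon. Going by the values given here, only one measured step bears on this change, the modest 2.5-fold lower number from compound 1 to compound 2 (0.40 log units; beyond the scatter), and it involves a different replacement. Among the compounds with values here, a small move towards a higher number is therefore expected in this assay, no larger than that step. The estimated step is a 1.6-fold higher number from compound 2 to compound 3 (0.20 log units; within the scatter). For compound 3 the expected value is 1.6 nM, with an estimated range of 0.6 nM to 4.5 nM.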

Compound 3, dissociation constant: 7.94 nM
Estimate against measurement, compound 3: 5.0-fold (0.70 log units) below; the measured number lies above the stated range.
By their numbers in this assay, from the lowest: compound 2; then compound 1; then compound 3.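

In this assay, the aryl group on the oxygen matters more than the earlier acetyl to tert-butyl change suggested: naphthalen-2-yl gives a 7.9-fold higher number from compound 2 to compound 3 (0.90 log units; beyond the scatter) and also a 3.2-fold higher number from compound 1 to compound 3 (0.50 log units; beyond the scatter), both beyond the scatter. The heavy-atom count stays the same while a second six-membered aromatic ring enters, so that count alone does not track the read-out. Nothing available here explains the rise. Still open, on these data alone, is whether naphthalen-1-yl on the same oxygen would read like naphthalen-2-yl. Also open, as far as these compounds go, is whether a phenyl ring carrying an amine or a carboxylic acid would fall nearer compound 2 or compound 3.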